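Para substituent on the aryl ring: chloro to 1,1-difluoroethyl

The source may report more compounds than this note shows. Statements on the series, on what has been measured and on what is new or still open speak of the compounds shown alone.

Measured so far:
Compound 1 `Cc1c(-c2ccccc2)nsc1NC(=O)[C@@H]1C[C@H]1C` gives 65 nM in an in vitro functional assay on AV12 cells for antagonist activity at metabotropic glutamate receptor 1 (Homo sapiens), read by FLIPR and calcium flux; a higher number here means a weaker inhibitor, a lower number a stronger inhibitor.
Compound 2 `Cc1c(-c2ccc(Cl)cc2)nsc1NC(=O)[C@@H]1C[C@H]1C` gives 9 nM in this assay.

Going by the values given here, compound 2 holds the lowest of the two numbers in this assay; its nearest neighbour is compound 1, and the only step recorded, a 7.2-fold lower number from compound 1 to compound 2 (0.86 log units; beyond the scatter), is the one that separates them. Compound 3 `Cc1c(-c2ccc(C(C)(F)F)cc2)nsc1NC(=O)[C@@H]1C[C@H]1C` differs from compound 2 by 1,1-difluoroethyl in place of chloro on an aromatic carbon. Among the compounds with values here, the one measured step that bears on this position is a 7.2-fold lower number from compound 1 to compound 2 (0.86 log units; beyond the scatter), which exchanged hydrogen for chloro at the same aromatic carbon, para to a large group. Within the data shown here, no step yet compares two substituents against each other at that carbon, so the size of the coming change cannot be read directly from the series. Given that a substituent at this place is retained rather than removed, compound 3 should give a step that is estimated at a 1.7-fold higher number from compound 2 to compound 3 (0.22 log units; within the scatter), a shift that may well remain within the scatter, with weakening somewhat more likely than strengthening. Compound 3 is therefore expected at about 15 nM in this assay, within a range of 4 nM to 50 nM.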

Compound 3, half-maximal inhibitory concentration: 67 nM
Estimate against measurement, compound 3: 4.5-fold (0.65 log units) below; measured number outside the range, above it.
By their numbers in this assay, from the lowest: compound 2; then compounds 1 and 3 (each within the scatter of the next).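

In this assay, the gain seen with chloro at this aromatic carbon does not extend to every group placed there: a 7.4-fold higher number from compound 2 to compound 3 (0.87 log units; beyond the scatter) shows that chloro and 1,1-difluoroethyl are not interchangeable at this position, so keeping a substituent on this carbon does not by itself keep the lower number. Against hydrogen at the same carbon, 1,1-difluoroethyl gives a 1.0-fold higher number from compound 1 to compound 3 (0.01 log units; within the scatter), so this group offers no measurable advantage over having no substituent there, and of the two groups tested only chloro separates from hydrogen beyond the scatter. Nothing available here accounts for the difference between chloro and 1,1-difluoroethyl.

With only these two groups at this carbon, the compounds shown leave open whether the low number is particular to chloro or is shared by groups such as fluoro, bromo, methyl, ethyl or trifluoromethyl. As far as these compounds go, the amide portion is also the same in all three compounds, so it remains open whether the same difference between chloro and hydrogen would appear with another acyl group, such as acetyl, in its place.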